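Hydrazone Series in Mouse Central Nervous System Inhibition

A few compounds are considered here, and "the series" means these few. Any claim that something is new, unique, unknown or untested is made for them only; others in the source may bear on it.

Compound 1 `CCN(CC)CCN1N=C(c2ccc(Br)cc2)CC2=C1CC(C)(C)CC2=O`: 26%
Compound 2 `CC1(C)CC(=O)C(CC(=O)c2ccccc2)=C(NNC(=O)c2ccncc2)C1`: 1%

Of the compounds shown here, two have been measured in a functional assay on the whole organism (Central nervous system, strain CF) for inhibition, with Mus musculus as the target, with a stated time of 15 min, at a dose of 500 mg/kg by the oral route; a higher number here means more inhibition at the dose given (going by the name of the read-out), a lower number less inhibition. Compound 1 gives 26% in this assay, while compound 2 gives 1%, the lower of the two numbers, and the gap between them lies beyond the usual scatter.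

The next compound, compound 3 `CC1(C)CC(=O)C(CC(=O)c2ccccc2)=C(NNc2ccncc2)C1`, keeps the core of compound 2 and differs only at the hydrazine end: pyridin-4-yl in place of (pyridin-4-yl)carbonyl on an amine nitrogen. Within the data shown here, no pair of measured compounds separated by a single change is available, so the size of this step cannot be read from the data. Because compound 2 already sits at 1%, there is little room to fall, and any rise is expected to stay small. The step from compound 2 to compound 3 is estimated as a number 7 percentage points higher from compound 2 to compound 3 (within the scatter), within the scatter. Compound 3 is therefore expected to give about 8%, in a range from 0% to 28%.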

Compound 3, a percentage reported as inhibition, in the whole organism at one dose (the size of the read-out at that dose, not a potency): 1%
Estimate against measurement, compound 3: 7 percentage points above; the measured number falls inside the stated range.
By their numbers in this assay, from the lowest: compounds 2 and 3 (each within the scatter of the next); then compound 1.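

Among these compounds, on an amine nitrogen, pyridin-4-yl in place of (pyridin-4-yl)carbonyl gives no change at the digits printed from compound 2 to compound 3 (within the scatter) in this assay, and this is the first step that can be read at a single place. It shows that, on this core, the carbonyl can leave this position without the number moving beyond the scatter, although both compounds lie so low in the read-out that a further fall could hardly be seen. Nothing on hand explains this result.

From the compounds shown here alone, it remains open whether a simple alkyl group, a longer chain or a carboxylic acid on the same amine nitrogen would lift the number above that of compound 2. Going by these compounds, it also remains open whether a plain phenyl ring there would read any differently from pyridin-4-yl.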